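The source may report more compounds than this note shows. Statements on the series, on what has been measured and on what is new or still open speak of the compounds shown alone.

Series notes. Compound 1 `CCCc1nnc(SCc2ccccc2Cl)n1N1C(=O)c2ccccc2C1=O` carries a propyl group on the shared core. In a functional assay on A549 cells (Homo sapiens) for cytotoxicity, read by MTT assay, with a stated time of 48 h (on this read-out higher numbers stand for weaker inhibition and lower numbers for stronger inhibition), compound 1 reaches only the limit of the assay, > 200000 nM. Compound 2 `COc1cc(-c2nnc(SCc3ccccc3Cl)n2N2C(=O)c3ccccc3C2=O)cc(OC)c1OC` carries a 3,4,5-trimethoxyphenyl in place of the propyl. In this assay compound 2 likewise returns only a limit, > 200000 nM. The step that the two limits leave unreadable from compound 1 to compound 2 cannot be read because of the limit of > 200000 nM in this assay, at which 2 of the 2 values shown sit. Compound 2 therefore stands at the limit, with no number that would place it against compound 1.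

Compound 3 `COc1ccc(C(=O)CSc2nnc(-c3cc(OC)c(OC)c(OC)c3)n2N2C(=O)c3ccccc3C2=O)cc1` differs from compound 2 by (4-methoxyphenyl)carbonyl in place of 2-chlorophenyl on a saturated chain carbon bound to a sulfur. For the measured compounds named here, no measured step touches this position; the only measured step, a step that the two limits leave unreadable from compound 1 to compound 2, changes a different site and is itself unreadable, so it gives no guide to the size or direction of the change in this assay on going to compound 3. The expectation rests on compound 2 sitting at the limit > 200000 nM. Compound 3 is expected to stay at or close to the limit, an estimated 250000 nM with a range of 60000 nM to 1000000 nM. The expected step is a step that the limit leaves unreadable from compound 2 to compound 3, which is no more than a carry-over of the limit.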

Compound 3, half-maximal inhibitory concentration: 30000 nM
Compound 3: middle estimate off by 8.3-fold (0.92 log units), on the high side; measured number below the stated range.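

In this assay, for the compounds shown here, the change on the saturated chain carbon bound to a sulfur, (4-methoxyphenyl)carbonyl in place of 2-chlorophenyl, gives an at least 6.6-fold lower number from compound 2 to compound 3 (0.82 log units; beyond the scatter) and is the first readable step, with compound 3 the first compound to carry a number rather than a limit. This position therefore responds to a change in this assay, which the earlier pair could not show, as the step between the propyl and 3,4,5-trimethoxyphenyl compounds cannot be read. Going by these compounds, the true size of the new step stays open on the weak side, and it can be stated only as a minimum: the limit of > 200000 nM in this assay, at which 2 of the 3 values shown sit.

The compounds shown leave open which part of the exchange carries the shift, as the carbonyl and the methoxy enter together while the chlorine leaves, so a plain phenylcarbonyl or a 4-chlorophenylcarbonyl group at this place would be needed to separate them. Also open, on these data alone, are whether the shift holds with propyl in place of the 3,4,5-trimethoxyphenyl on the shared core, and how a carboxylic acid or an amine on the same chain would read.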